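The source may hold more compounds than are shown below. What is called first, only, known or untested is meant among the compounds shown, and "the series" means these compounds.

Compound 3, `CC(NC(=O)c1ccc(C#Cc2ccccc2)cc1)C(=O)NO`, holds the highest number of the three compounds in a physicochemical assay for solubility (a lower number here means a less soluble compound, a higher number a more soluble compound), where compound 3 gives 29000 nM. Compound 1, `C#CCNC(=O)C[C@H](NC(=O)c1ccc(C#Cc2ccccc2)cc1)C(=O)NO`, stands nearest to it; in this assay compound 1 gives 8000 nM. Compound 2, `CSC[C@H](NC(=O)c1ccc(C#Cc2ccccc2)cc1)C(=O)NO`, lies furthest away, and in this assay compound 2 gives 2000 nM.

Compound 4, `O=C(CNC(=O)c1ccc(C#Cc2ccccc2)cc1)NO`, differs from compound 3 by one change: hydrogen in place of methyl on a saturated chain carbon bound to an amide-type nitrogen and a carbonyl carbon.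

The two measured steps do not touch this position directly. Both alter the group on the saturated chain carbon that sits between the amide-type nitrogen and the carbonyl carbon, and they pull in opposite directions: a 4.0-fold lower number from compound 1 to compound 2 (0.60 log units; beyond the scatter), whereas a 15-fold higher number from compound 2 to compound 3 (1.16 log units; beyond the scatter). Neither step removes a single carbon without adding anything, so they offer only loose guidance. Since the change to compound 4 is a very small one, the expected step is a 1.2-fold higher number from compound 3 to compound 4 (0.08 log units; within the scatter), likely within the scatter. The expectation for compound 4 in this assay is therefore 35000 nM, with a plausible range from 15000 nM to 80000 nM.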

Compound 4, solubility: 21000 nM
Compound 4: middle estimate off by 1.7-fold (0.22 log units), on the high side, within the range that was stated.
By their numbers in this assay, from the lowest: compound 2; then compound 1; then compounds 4 and 3 (each within the scatter of the next).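

On the saturated chain carbon bound to an amide-type nitrogen and a carbonyl carbon, this assay does not separate hydrogen from methyl (a 1.4-fold lower number from compound 3 to compound 4 (0.14 log units; within the scatter)). Larger groups at this carbon do separate from hydrogen: putting hydrogen in place of (methylsulfanyl)methyl gives the biggest step here (an 11-fold higher number from compound 2 to compound 4 (1.02 log units; beyond the scatter)), while putting it in place of (propargylcarbamoyl)methyl gives a smaller one (a 2.6-fold higher number from compound 1 to compound 4 (0.42 log units; beyond the scatter)). No measurement at hand speaks to why these steps differ in size.

The compounds shown leave open what an amine or a carboxylic acid on this carbon would do. They also leave open whether a plain ethyl or propyl chain would stay level with hydrogen and methyl or fall toward compound 2.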